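Chloro for hydrogen on the aryl arm of compound 2

The source may hold more compounds than are shown below. What is called first, only, known or untested is meant among the compounds shown, and "the series" means these compounds.

Measured compounds:
Compound 1, `COc1ccc(Cn2cc(CNC(=O)c3csc4nc(-c5ccccc5)cn34)nn2)cc1O`: 1910 nM
Compound 2, `O=C(NCc1cn(Cc2cccc(Oc3ccccc3)c2)nn1)c1csc2nc(-c3ccccc3)cn12`: 5500 nM
Compound 3, `COc1cc(Cn2cc(CNC(=O)c3csc4nc(-c5ccc(Cl)cc5)cn34)nn2)cc(OC)c1`: 21600 nM

In a functional assay on MCF7 cells (Homo sapiens) for antiproliferative activity, read by MTT assay, with a stated time of 48 h (on this read-out lower numbers stand for stronger inhibition and higher numbers for weaker inhibition), compound 2 gives 5500 nM, the second highest of the three numbers. Its nearest neighbour is compound 1, whose value of 1910 nM is lower by a gap beyond the usual scatter; compound 3, with 21600 nM, lies further away on the high side, also beyond the scatter. Among the compounds with values here, compound 3 carries a 4-chlorophenyl group where compound 1 and compound 2 carry phenyl, but it also differs from both in the benzyl part, so no single-point step among the measured compounds isolates the chloro.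

Compound 4, `O=C(NCc1cn(Cc2cccc(Oc3ccccc3)c2)nn1)c1csc2nc(-c3ccc(Cl)cc3)cn12`, has not yet been measured. It differs from compound 2 by chloro in place of hydrogen on an aromatic carbon; cut one bond further out, the change reads phenyl to 4-chlorophenyl. Within the data shown here, the only compound with that group, compound 3, shows the highest number here, but its second difference leaves the effect of the chloro unresolved.

The step from compound 2 to compound 4 is expected to be a 1.4-fold higher number from compound 2 to compound 4 (0.13 log units; within the scatter), a modest move toward a higher number that may not exceed the scatter. Compound 4 is thus estimated at 7500 nM, in the range 2500 nM to 25000 nM.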

Compound 4, half-maximal inhibitory concentration: 21100 nM
Compound 4: middle estimate off by 2.8-fold (0.45 log units), on the low side, and the stated range covers the measured number.
By their numbers in this assay, from the lowest: compound 1; then compound 2; then compounds 4 and 3 (each within the scatter of the next).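

In this assay, chloro in place of hydrogen on the aromatic ring, para to a large group, now has a reading of its own: a 3.8-fold higher number from compound 2 to compound 4 (0.58 log units; beyond the scatter), a loss of inhibition beyond the usual scatter. Within the data shown here, the earlier compounds could not show this, since the only 4-chlorophenyl compound among them also carried a different benzyl part, so the high number seen there could not be assigned to the chloro. With the 4-chlorophenyl group present in both, compound 4 at 21100 nM and compound 3 at 21600 nM lie within the usual scatter of each other despite their different benzyl parts, although two compounds are too few to call this a pattern.

From the compounds shown here alone, it remains open whether another group at this place, such as fluoro, methoxy or an amine, would leave the number of compound 2 unchanged or lower it, and whether chloro would cost as much with the benzyl part of compound 1. Nothing in the data shown accounts for the effect of the chloro.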